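The source may report more compounds than this note shows. Statements on the series, on what has been measured and on what is new or still open speak of the compounds shown alone.

Working notes on the series

Compound 3 `Cc1cccc(NC(=O)COc2ccc3cc(/C=C4/SC(=O)NC4=O)ccc3c2)n1` in an assay on isolated protein for inhibition of histone deacetylase 4 (Homo sapiens), with a stated time of 1 h (a lower number here means a stronger inhibitor, a higher number a weaker inhibitor), gives 1100 nM, level with compound 1 `Cc1ccc(NC(=O)COc2ccc3cc(/C=C4/SC(=O)NC4=O)ccc3c2)cc1Cl`, which gives 1100 nM; together these are the lowest of the three numbers. Compound 2 `O=C(COc1ccc2cc(/C=C3/SC(=O)NC3=O)ccc2c1)Nc1cccc(Cl)c1` gives 3800 nM; the step of a 3.5-fold lower number from compound 2 to compound 3 (0.54 log units; beyond the scatter) is modest but beyond the scatter, while no change at the digits printed from compound 1 to compound 3 (within the scatter) stays within it.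

Compound 4 `COc1cccc(NC(=O)COc2ccc3cc(/C=C4/SC(=O)NC4=O)ccc3c2)c1` is not yet measured. Its difference from compound 3: 3-methoxyphenyl in place of 6-methylpyridin-2-yl on an amide-type nitrogen. For the measured compounds named here, no measured step exchanges a 6-methylpyridin-2-yl for a 3-methoxyphenyl, so nothing bears on it directly. The closest information is that the 3-chlorophenyl amide of compound 2 lies above the others, and that a 3.5-fold higher number from compound 1 to compound 2 (0.54 log units; beyond the scatter) shows a single change on the aromatic ring shifting the number by a modest amount. A 3-methoxyphenyl resembles compound 2 more than compound 3, so compound 4 is expected to sit between them, a step of a 2.3-fold higher number from compound 3 to compound 4 (0.36 log units; beyond the scatter). Compound 4 is estimated at 2500 nM, with a range of 900 nM to 7000 nM.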

Compound 4, half-maximal inhibitory concentration: 1600 nM
Beside the measured number, compound 4's estimate is 1.6-fold (0.19 log units) above it, within the range that was stated.
By their numbers in this assay, from the lowest: compounds 1, 3 and 4 (each within the scatter of the next); then compound 2.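

In this assay, the amide-type nitrogen carries 3-methoxyphenyl, 6-methylpyridin-2-yl or 3-chloro-4-methylphenyl without a separation beyond the scatter: a 1.5-fold higher number from compound 3 to compound 4 (0.16 log units; within the scatter) and a 1.5-fold higher number from compound 1 to compound 4 (0.16 log units; within the scatter) both stay within it, so a ring of carbon only with methoxy reads the same as these two other aryl groups. Methoxy in place of chloro on an aromatic carbon is a single exchange that does register, a 2.4-fold lower number from compound 2 to compound 4 (0.38 log units; beyond the scatter), and compound 2 now stands apart from all three other compounds, which shows that the 3-chlorophenyl amide is the outlier here rather than ring carbon-only amides as a class. Nothing on hand accounts for these steps.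

The compounds shown leave open what an amine or a carboxylic acid on that aromatic ring would do to the number. They also leave open whether adding a methyl to the 3-methoxyphenyl would follow the step seen with the chloro pair, a 3.5-fold higher number from compound 1 to compound 2 (0.54 log units; beyond the scatter).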